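A few compounds are considered here, and "the series" means these few. Any claim that something is new, unique, unknown or untested is made for them only; others in the source may bear on it.

In an ADME assay on Huh-7 cells (Homo sapiens) for cytotoxicity, with a stated time of 72 h (a lower number here means that less compound is tolerated, a higher number that more compound is tolerated), the measured compounds are:

- compound 1 `CCCC(C)n1nc(-c2cccs2)c(O)c(C2=NS(=O)(=O)c3cc(NS(C)(=O)=O)ccc3N2)c1=O`: > 33000 nM, a limit
- compound 2 `CCC(C)n1nc(-c2cccs2)c(O)c(C2=NS(=O)(=O)c3cc(NS(C)(=O)=O)ccc3N2)c1=O`: > 33000 nM, a limit
- compound 3 `CC(C)(C)Cn1nc(-c2cccs2)c(O)c(C2=NS(=O)(=O)c3cc(NS(C)(=O)=O)ccc3N2)c1=O`: > 1000 nM, a limit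

Compound 3 has only a limit and no number. This is the limit of > 1000 nM in this assay, at which 1 of the 3 values shown sits. Compound 1 and compound 2 stand at the limit of > 33000 nM in this assay, at which 2 of the 3 values shown sit.

The next compound is compound 4 `CS(=O)(=O)Nc1ccc2c(c1)S(=O)(=O)N=C(c1c(O)c(-c3cccs3)nn(CC3(C(F)(F)F)CCC3)c1=O)N2`, not yet measured in this assay. It carries 1-(trifluoromethyl)cyclobutyl in place of tert-butyl on a saturated chain carbon bound to an aromatic nitrogen. Cut one bond further out, this reads neopentyl to (1-(trifluoromethyl)cyclobutyl)methyl.

The closest measured changes are those that bring in the neopentyl group on the aromatic nitrogen. These are a step that the two limits leave unreadable from compound 1 to compound 3 and a step that the two limits leave unreadable from compound 2 to compound 3. The remaining change, a step that the two limits leave unreadable from compound 1 to compound 2, is further from this one. None of these has a readable size, so no measured size or direction carries over to the new group.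

No number has yet been recorded for any compound in the series, and compound 4 is expected to return a limit as well. The expected step is a step that the limit leaves unreadable from compound 3 to compound 4, an estimate with no measured size behind it. For compound 4 the estimated value is 20000 nM, with an expected range from 3000 nM to 50000 nM.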

Compound 4, half-maximal cytotoxic concentration: > 1000 nM
Compound 4: only a limit was reported; the forecaster's own chance of this, stated with the estimate: 80%; the middle value lies beyond the limit too.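

In this assay compound 4 gives the limit > 1000 nM and no number. The steps from compound 1, compound 2 and compound 3 to compound 4 cannot be read: all four values are limits. The compounds shown leave open where the half-maximal cytotoxic concentration of each lies, and whether (1-(trifluoromethyl)cyclobutyl)methyl in place of neopentyl changes it at all.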